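Carbamoyl to (Ethylsulfanyl)carbonyl on a Shared Core

The source may hold more compounds than are shown below. What is called first, only, known or untested is meant among the compounds shown, and "the series" means these compounds.

Of the compounds shown here, three built on one core have been measured: compound 1 `CC(=O)C1=C(C)NC(=O)NC1c1ccoc1`, compound 2 `CCCC(=O)C1=C(C)NC(=O)NC1c1ccoc1` and compound 3 `CC1=C(C(N)=O)C(c2ccoc2)NC(=O)N1`. In an assay on membranes from HeLa cells for displacement of a labelled ligand from adenosine receptor A3 (Homo sapiens), read by scintillation counting, with a stated time of 180 min, tested at 1 uM (a higher number here means more inhibition at the concentration tested (going by the name of the read-out), a lower number less inhibition), compound 1 gives 2%, compound 2 gives 2% and compound 3 gives 2%. Compound 3 therefore stands level with compounds 1 and 2. The steps of no change at the digits printed from compound 1 to compound 3 (within the scatter) and no change at the digits printed from compound 2 to compound 3 (within the scatter) show that swapping the group on the carbonyl carbon left the read-out unchanged, as did no change at the digits printed from compound 1 to compound 2 (within the scatter). Compound 4 `CCSC(=O)C1=C(C)NC(=O)NC1c1ccoc1` differs from compound 3 by ethylsulfanyl in place of amino on a carbonyl carbon, which one bond further out reads carbamoyl to (ethylsulfanyl)carbonyl. Since every measured step at this carbonyl carbon stayed within the scatter, no step beyond the scatter is expected in this assay. Compound 4 is estimated at 2%, between -8% and 12%. The expected step is no change at the digits printed from compound 3 to compound 4 (within the scatter).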

Compound 4, a percentage reported as inhibition, at one concentration (the size of the read-out at that concentration, not a potency): 1%
The estimate for compound 4 lay 1 percentage points above the measured number, within the range that was stated.
By their numbers in this assay, from the lowest: compounds 4, 1, 2 and 3 (each within the scatter of the next).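

In this assay ethylsulfanyl on the carbonyl carbon reads the same as amino (a number 1 percentage points lower from compound 3 to compound 4 (within the scatter)), as propyl (a number 1 percentage points lower from compound 2 to compound 4 (within the scatter)) and as methyl (a number 1 percentage points lower from compound 1 to compound 4 (within the scatter)). A sulfur atom linking the chain to this carbonyl carbon, new among these compounds, therefore moves the read-out no further than the scatter. Nothing measured here offers an explanation for this. All four numbers are small, so these compounds do not show whether any group at this place can raise the read-out. As far as these compounds go, a carboxylic acid or a longer chain on this carbonyl carbon remains open, as does a different group in place of the ring on the shared core.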